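This account rests on a few compounds, and the source may have more. Where it says the series, first, only, none or still open, it means among the compounds named here.

Measured so far:
Compound 1, `CN(C)C(=O)c1cccnc1NCCCN1CCN(c2ccccc2-c2ncco2)CC1`: 0.316 nM
Compound 2, `CCCc1ccccc1N1CCN(CCCNc2ncccc2C(=O)N(C)C)CC1`: 0.2 nM

Among the measured compounds shown here, compound 2 has the lowest of the two numbers in a functional assay for antagonist activity at Alpha-1A adrenergic receptor (Oryctolagus cuniculus) (a higher number here means weaker binding, a lower number tighter binding), but its nearest neighbour is compound 1, and the only measured step, a 1.6-fold lower number from compound 1 to compound 2 (0.20 log units; within the scatter), falls within the scatter, so the two compounds cannot be told apart on these numbers.

Compound 3, `CN(C)C(=O)c1cccnc1NCCCN1CCN(c2ccccc2C2CC2)CC1`, differs from compound 2 by cyclopropyl in place of propyl on an aromatic carbon. For the measured compounds named here, the one measured step touches the same aromatic carbon, yet it exchanged a different pair of groups and stayed within the scatter; no measured pair exchanges propyl for cyclopropyl anywhere. The data therefore give no ground for a change in either direction, and the expectation is that the number of compound 3 stays close to that of compound 2, with a 1.3-fold higher number from compound 2 to compound 3 (0.10 log units; within the scatter) expected to lie within the scatter. Compound 3 is estimated at 0.25 nM in this assay, with a range from 0.1 nM to 0.7 nM.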

Compound 3, dissociation constant: 0.631 nM
The estimate for compound 3 lay 2.5-fold (0.40 log units) below the measured number, within the range that was stated.
By their numbers in this assay, from the lowest: compounds 2, 1 and 3 (each within the scatter of the next, the first and the last beyond it).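

In this assay, among the compounds shown here, the exchange of propyl for cyclopropyl on an aromatic carbon, ortho to a large group, gives the first step that lies beyond the scatter, with a 3.2-fold higher number from compound 2 to compound 3 (0.50 log units; beyond the scatter) counted as modest. The two groups have the same count of 3 heavy atoms, all carbon, and the enters group differs in holding a three-membered ring, so this position can register a change even when the count of heavy atoms stays the same, which the step between compound 1 and compound 2 had not shown. The other new step, a 2.0-fold higher number from compound 1 to compound 3 (0.30 log units; within the scatter) lies within the scatter, so cyclopropyl and 1,3-oxazol-2-yl cannot be told apart here, and only propyl and cyclopropyl are separated; nothing available explains that separation.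

The compounds shown leave open whether the step belongs to the ring as such or would also appear with an open branched group such as isopropyl, or with a larger ring such as cyclobutyl. They also leave open how a shorter chain such as ethyl, or an amine or a methoxy group, would stand on this same aromatic carbon.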